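The compounds below may be only part of what the source reports. "The series", "measured", "known", "first", "only" and "open" are said of these compounds alone.

Compound 1, `COCCCCCCCCCCCCCCC/C=C1/CC(CO)(COC(=O)C(C)(C)C)OC1=O`, gives 2.13 ug/mL in a functional assay on SK-MEL-5 cells (Homo sapiens) for antiproliferative activity; a higher number here means a weaker inhibitor of growth, a lower number a stronger inhibitor of growth. Of the two plain numbers recorded in this assay it is the higher, yet its nearest neighbour, compound 2, `COCCCCCCCCCCCCCCC/C=C1\CC(CO)(COC(=O)C(C)(C)C)OC1=O`, gives 1.75 ug/mL, and the move a 1.2-fold lower number from compound 1 to compound 2 (0.09 log units; within the scatter) stays within the scatter; the two differ only in how a double bond is drawn, as the fact that one of compounds 1 and 2 is drawn with a defined configuration and the other without, at the place where they differ records. Compound 3, `CCCCCCCCC(O)CCCCCC/C=C1\CC(CO)(COC(=O)C(C)(C)C)OC1=O`, reaches only the assay limit of > 10 ug/mL in this assay.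

Compound 4, `CC(C)(C)C(=O)OCC1(CO)C/C(=C/CCCCCCCCCCCCCCC=O)C(=O)O1`, has not been measured. It differs from compound 1 by formyl in place of methoxymethyl on a saturated chain carbon, ten or more bonds along the chain from a double-bonded chain carbon. Within the data shown here, no measured step reproduces this change. The only one that alters the oxygen-bearing end of the chain is an at least 5.7-fold higher number from compound 2 to compound 3 (0.75 log units; beyond the scatter), where 1-hydroxynonyl in place of 9-methoxynonyl cost at least a modest amount, the result sitting at the limit of > 10 ug/mL in this assay, at which 1 of the 3 values shown sits. The step from compound 1 to compound 2, by contrast, shows that the drawing of the double bond hardly matters. Taking the one substantial precedent as a guide, but noting that formyl keeps one hydrogen-bond acceptor and no donor, a modest weakening is expected, a 1.9-fold higher number from compound 1 to compound 4 (0.27 log units; within the scatter), and compound 4 is estimated at 4 ug/mL, with a range from 1.5 ug/mL to 10 ug/mL.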

Compound 4, concentration for 50% growth inhibition: > 10 ug/mL
Compound 4 gave a limit, no number; the forecaster's own chance of this, stated with the estimate: 15%; middle value at least 2.5-fold (0.39 log units) away from the limit.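

In this assay, formyl in place of methoxymethyl on a saturated chain carbon, ten or more bonds along the chain from a double-bonded chain carbon, gives an at least 4.6-fold higher number from compound 1 to compound 4 (0.67 log units; beyond the scatter), so the far end of this chain is not a place where changes pass without effect. Compound 4 gives > 10 ug/mL, which is a limit of the assay and not a number. The earlier loss at the oxygen-bearing end of the chain came with 1-hydroxynonyl in place of 9-methoxynonyl, whereas here the groups that leave and enter both count 0 hydrogen-bond donors and 1 hydrogen-bond acceptor, so these matching counts do not preserve the activity, and a second compound now ends at the limit: the limit of > 10 ug/mL in this assay, at which 2 of the 4 values shown sit.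

As far as these compounds go, since the result is a limit, the full size of the loss stays unknown, and a single change at this chain end cannot show whether methoxy itself is required. From the compounds shown here alone, how a carboxylic acid, an amine or a longer chain carrying the same methoxy end would behave in this assay remains open.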